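The compounds below may be only part of what the source reports. "The series", "measured", "known", "first", "only" and "open" are said of these compounds alone.

Of the compounds shown here, three of the shared core have been measured in an assay on HEK293 cells for activation of Kir3.1/Kir3.2 (Homo sapiens), read by thallium flux; a lower number here means that less compound is needed, a higher number that more compound is needed for the effect. Compound 1 `Cc1cc(NC(=O)Cn2nnc(-c3ccccc3)n2)n(C(C)C)n1` gives 556 nM. Compound 2 `Cc1cc(NC(=O)Cn2nnc(-c3ccccc3)n2)n(C2CC2)n1` reaches only the limit of the assay, > 5000 nM, and no number is known for it. Compound 3 `Cc1cc(NC(=O)Cn2nnc(-c3cccc(Cl)c3)n2)n(C2CCCCC2)n1` gives 300 nM, the lowest of the two numbers, though its gap to compound 1 lies within the scatter of this assay. Among the measured compounds shown here, the one step measured within this set, an at least 8.9-fold higher number from compound 1 to compound 2 (0.95 log units; beyond the scatter), involves a cyclopropyl in place of isopropyl on an aromatic nitrogen of the core; its size is bounded only by the limit of > 5000 nM in this assay, at which 1 of the 3 values shown sits.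

Compound 4 `Cc1cc(NC(=O)Cn2nnc(C3CC3)n2)n(C2CCCCC2)n1` is not yet measured. It differs from compound 3 in one place: cyclopropyl in place of 3-chlorophenyl on an aromatic carbon. For the measured compounds named here, the measured step concerns a different position, so no step bears directly on this change; the only guidance is that the one cyclopropyl introduced so far, in compound 2, coincided with a number at the limit. Compound 4 is therefore expected to give a higher number than compound 3 in this assay, a step of an 8.3-fold higher number from compound 3 to compound 4 (0.92 log units; beyond the scatter) in the weaker direction. Compound 4 is estimated at 2500 nM, within a range from 600 nM to 8000 nM, with a real chance that this assay reports only a limit.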

Compound 4, half-maximal effective concentration: > 3000 nM
Compound 4: a limit, no number; the forecaster's own chance of this, stated with the estimate: 35%; at least 1.2-fold (0.07 log units) between middle value and limit.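

The earlier step concerned the aromatic nitrogen, whereas this change, at the aromatic carbon between two ring nitrogen atoms, shows that the group here also matters in this assay: replacing 3-chlorophenyl with cyclopropyl gives an at least 10-fold higher number from compound 3 to compound 4 (1.00 log units; beyond the scatter), a step beyond the scatter. Compound 4 gives only a limit, > 3000 nM, so the step has a lower bound and no exact size: the limit of > 3000 nM in this assay, at which 1 of the 4 values shown sits. Cyclopropyl at two different places, in compound 2 and in compound 4, has now come with a limit each time, and no compound shown goes against this, although two compounds are too few to make it a rule.

The compounds shown do not separate the part played by the chlorine from that of the whole aromatic ring, and a plain phenyl, a 3-fluorophenyl or a longer chain such as n-butyl on this carbon, each with the rest of compound 3 kept, would be needed to tell these apart. From the compounds shown here alone, it also remains open whether an amine or a carboxylic acid on the 3-chlorophenyl ring would be tolerated at this position.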